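The compounds below may be only part of what the source reports. "The series", "measured", "known", "first", "only" and "open" are said of these compounds alone.

In a functional assay on MDA-MB-231 cells (Homo sapiens) for antiproliferative activity, read by sulforhodamine B assay (a higher number here means a weaker inhibitor of growth, a lower number a stronger inhibitor of growth), compound 3 `CC(C)(C)CCOc1cccc(O)c1C(=O)/C=C/c1ccc(O)cc1` gives 2380 nM, the lowest number measured in this small set. Compound 2 `CC(C)(C)CCOc1cccc(O)c1C(=O)/C=C/c1ccc(C(=O)O)cc1` gives 11200 nM. Compound 1 `COc1cccc(OCCC(C)(C)C)c1C(=O)/C=C/c1ccc(O)cc1` gives > 30000 nM, which is a limit of the assay and not a number. Compound 4 `CC(C)(C)CCOc1cccc(O)c1C(=O)/C=C/c1ccc(S(N)(=O)=O)cc1` carries sulfamoyl in place of hydroxy on an aromatic carbon, para to a large group: sulfamoyl in place of hydroxy on an aromatic carbon. Among the compounds with values here, one measured step concerns that same place, a 4.7-fold lower number from compound 2 to compound 3 (0.67 log units; beyond the scatter), with hydroxy in place of carboxy. The other, an at least 12-fold lower number from compound 1 to compound 3 (1.10 log units; beyond the scatter), is hydrogen in place of methyl on an oxygen, a change that compound 4 does not touch. A modest rise in the number is therefore expected, an estimated 2.5-fold higher number from compound 3 to compound 4 (0.40 log units; beyond the scatter). For compound 4 the expected value is 6000 nM, within an estimated range of 2000 nM to 20000 nM.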

Compound 4, concentration for 50% growth inhibition: 2110 nM
Estimate against measurement, compound 4: 2.8-fold (0.45 log units) above; the measured number falls inside the stated range.
By their numbers in this assay, from the lowest: compounds 4 and 3 (each within the scatter of the next); then compound 2. At a limit, above all of these: compound 1.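

In this assay, sulfamoyl and hydroxy cannot be told apart at this place on the aromatic ring (a 1.1-fold lower number from compound 3 to compound 4 (0.05 log units; within the scatter)). Carboxy now stands apart from both groups, not only from hydroxy (a 5.3-fold lower number from compound 2 to compound 4 (0.72 log units; beyond the scatter)). Nothing shown explains why sulfamoyl and hydroxy match here or why carboxy differs.

As far as these compounds go, what an amine or an amide would give at this place remains open. So does whether compound 4 would keep its number with methyl on the oxygen that differs between compound 1 and compound 3.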